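Allyl-substituted core series: vinyl to (methoxymethoxy)methyl

The source may hold more compounds than are shown below. What is called first, only, known or untested is meant among the compounds shown, and "the series" means these compounds.

Measured compounds:
compound 1, `C=CCn1c(-c2ccc(OC)cc2C=C)cc2ccccc2c1=O`, 17200 nM
compound 2, `C=CCn1c(-c2cc(OC)c(OC)cc2C=O)cc2ccccc2c1=O`, 76300 nM
compound 3, `COCOCc1cc(OC)c(OC)cc1-c1cc2ccccc2c(=O)[nH]1`, 85100 nM

In a functional assay on A549 cells (Homo sapiens) for cytotoxicity, read by MTT assay, with a stated time of 48 h (on this read-out lower numbers stand for stronger inhibition and higher numbers for weaker inhibition), compound 1 gives the lowest of the three numbers; compound 2 stands beyond the scatter above it, and compound 3 stands beyond the scatter above it as well. Going by the values given here, compound 3 carries the (methoxymethoxy)methyl group on a differently substituted ring and a different nitrogen substituent on the shared core, so no single step connects it to compound 1; its number and that of compound 1 are simply what the two show.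

Compound 4, `C=CCn1c(-c2ccc(OC)cc2COCOC)cc2ccccc2c1=O`, is not yet measured in this assay. Relative to compound 1 the change is (methoxymethoxy)methyl in place of vinyl on an aromatic carbon. Among the compounds with values here, no step between measured compounds isolates this change. Since both compound 2 (76300 nM) and compound 3 (85100 nM) sit well above compound 1, a step of moderate size toward a higher number is expected in this assay; an expected step of a 2.3-fold higher number from compound 1 to compound 4 (0.37 log units; beyond the scatter) follows. Compound 4 is estimated at 40000 nM, with a range from 15000 nM to 110000 nM.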

Compound 4, half-maximal inhibitory concentration: > 100000 nM
Compound 4 gave a limit, no number (the forecaster's own chance of this, stated with the estimate: 15%); middle value at least 2.5-fold (0.39 log units) from the limit.
By their numbers in this assay, from the lowest: compound 1; then compounds 2 and 3 (each within the scatter of the next). At a limit, above all of these: compound 4.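

In this assay, going by these compounds alone, (methoxymethoxy)methyl in place of vinyl on this aromatic carbon, ortho to a large group, gives an at least 5.8-fold higher number from compound 1 to compound 4 (0.76 log units; beyond the scatter), the first single change that can be read directly. The value for compound 4 is a limit of the assay, not a number, so this step has a lower bound but no known size: the limit of > 100000 nM in this assay, at which 1 of the 4 values shown sits. Of the two groups compared at this position, only vinyl gives a readable number, so the read-out is not indifferent to the group placed here.

The compounds shown leave open whether the shift comes from losing vinyl or from gaining (methoxymethoxy)methyl. They also leave open how an ethyl, hydroxymethyl or aminomethyl group would read at this position on the shared core.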